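Swapping an alkyne tail for a cyclobutyl ring

The compounds below may be only part of what the source reports. "The series", "measured", "known", "first", "only" and "open" are said of these compounds alone.

Measured so far:
compound 1 `C#CCCCn1c(Cc2cc(OC)c(OC)c(OC)c2)nc2c(N)nc(F)nc21` — 11000 nM
compound 2 `CC[C@H](C)Cn1c(Cc2cc(OC)c(OC)c(OC)c2)nc2c(N)nc(F)nc21` — 43700 nM
compound 3 `C#CCCCn1c(Cc2cc(OC)c(OC)c(OC)c2)nc2c(N)ncnc21` — 24000 nM

All three share one core and differ only in small side groups. In a functional assay on MCF7 cells (Homo sapiens) for antiproliferative activity (a higher number here means a weaker inhibitor, a lower number a stronger inhibitor), compound 3 gives 24000 nM, the second highest of the three numbers. It sits close to compound 2, within the usual scatter, and clearly above compound 1, as the step of a 2.2-fold higher number from compound 1 to compound 3 (0.34 log units; beyond the scatter) shows.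

Compound 4 `COc1cc(Cc2nc3c(N)ncnc3n2CC2CCC2)cc(OC)c1OC` has not yet been measured. It differs from compound 3 by cyclobutyl in place of but-3-yn-1-yl on a saturated chain carbon bound to an aromatic nitrogen.

Going by the values given here, one measured step bears on this: the step of a 4.0-fold higher number from compound 1 to compound 2 (0.60 log units; beyond the scatter) also replaces but-3-yn-1-yl with a saturated group of four carbon atoms at the same place, and the number went up moderately. Among the compounds with values here, the ring in compound 4 is a different saturated shape, so the comparison is loose, but it is the only guide available.

The expectation for compound 4 is therefore a modest rise in the number, that is, a weaker inhibitor, with the step of a 2.5-fold higher number from compound 3 to compound 4 (0.40 log units; beyond the scatter) estimated. Compound 4 is expected at 60000 nM, in a range from 25000 nM to 150000 nM.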

Compound 4, half-maximal inhibitory concentration: 45700 nM
Compound 4: middle estimate off by 1.3-fold (0.12 log units), on the high side; low and high end bracket the measured number.
By their numbers in this assay, from the lowest: compound 1; then compounds 3, 2 and 4 (each within the scatter of the next).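

In this assay, exchanging but-3-yn-1-yl for cyclobutyl on a saturated chain carbon bound to an aromatic nitrogen gives a 1.9-fold higher number from compound 3 to compound 4 (0.28 log units; within the scatter), so these compounds do not separate the open chain with its triple bond from the closed ring, although both groups hold 4 carbon atoms. The earlier saturated swap, a 4.0-fold higher number from compound 1 to compound 2 (0.60 log units; beyond the scatter), lay beyond the scatter, but it brought in sec-butyl rather than cyclobutyl and was made on compounds carrying a fluoro group, so the two steps do not test the same change. Nothing available explains why compound 3 and compound 4 cannot be told apart in this assay.

Going by these compounds, it remains open whether cyclobutyl would behave the same way on the fluoro-bearing core of compound 1, where the step of a 2.2-fold higher number from compound 1 to compound 3 (0.34 log units; beyond the scatter) shows that the fluoro group matters. Also open, on these data alone, is whether a larger cyclohexyl ring, or a chain ending in an amine, at this place would move the number beyond the scatter.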